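A few compounds are considered here, and "the series" means these few. Any claim that something is new, unique, unknown or untested is made for them only; others in the source may bear on it.

In an ADME assay on L02 cells (Homo sapiens) for cytotoxicity, read by CCK-8 assay, with a stated time of 6 days (on this read-out higher numbers stand for weaker inhibition and lower numbers for stronger inhibition), compound 1 `CC(O)c1ccc(C(=O)N[C@@H](C)Cn2ccc(-c3ccc(C#N)c(Cl)c3)n2)cc1` gives > 30000 nM, which is a limit and not a number. Compound 2 `CC(=O)c1ccc(C(=O)N[C@@H](C)Cn2ccc(-c3ccc(C#N)c(Cl)c3)n2)cc1` gives 15300 nM. Compound 3 `COC(=O)/C=C/C(=O)N[C@@H](C)Cn1ccc(-c2ccc(C#N)c(Cl)c2)n1` offers no starting point, as its entry reads "not determined" (no result reported).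

Compound 4 `C[C@@H](Cn1ccc(-c2ccc(C#N)c(Cl)c2)n1)Nc1cccnc1` differs from compound 3 by pyridin-3-yl in place of (2-(methoxycarbonyl)ethenyl)carbonyl on an amine nitrogen.

Within the data shown here, only one measured step exists, an at least 1.9-fold lower number from compound 1 to compound 2 (0.29 log units; that floor lies within the scatter). It is acetyl in place of 1-hydroxyethyl on an aromatic carbon, a different change at a different place, so it bears only weakly on this one. With no number for compound 3, no step size or direction can be expected in this assay. Among the measured compounds shown here, the expectation rests instead on the general level of the series, where compound 2 at 15300 nM is the only actual number. A result reported only as a limit remains a real possibility.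

For compound 4 the expected value is 20000 nM, with an estimated range of 8000 nM to 45000 nM.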

Compound 4, half-maximal inhibitory concentration: > 30000 nM
Compound 4 ended at the assay's limit; the forecaster's own chance of this, stated with the estimate: 40%; at least 1.5-fold (0.17 log units) between middle value and limit.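

With no number for compound 3 and only a limit for compound 4, no new step can be read between them in this assay. The compounds shown leave open how pyridin-3-yl compares with (2-(methoxycarbonyl)ethenyl)carbonyl on an amine nitrogen, and where compound 4 truly lies: the limit of > 30000 nM in this assay, at which 2 of the 4 values shown sit.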